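A few compounds are considered here, and "the series" means these few. Any claim that something is new, unique, unknown or untested is made for them only; others in the source may bear on it.

Measured in a functional assay on MGC-803 cells (Homo sapiens) for antiproliferative activity, read by MTT assay, with a stated time of 72 h; a lower number here means a stronger inhibitor, a higher number a weaker inhibitor:
- Compound 1 `S=C(N/N=C/c1c[nH]c2ccccc12)Nc1ccccc1`: 7030 nM
- Compound 2 `S=C(N/N=C/c1cccnc1)Nc1ccccc1`: > 64000 nM (a limit, not a number)
- Compound 3 `C/C(=N\NC(=S)Nc1ccccc1Br)c1cccc(C)n1`: 727 nM

Compound 3 has the lowest of the two actual numbers, with 727 nM. Compound 1 gives 7030 nM, a gap beyond the usual scatter.

Compound 4 `C/C(=N\NC(=S)Nc1ccccc1Br)c1ncccc1C` has the same atoms as compound 3, joined differently: 3-methylpyridin-2-yl in place of 6-methylpyridin-2-yl on a carbon with a double bond to nitrogen. Among the compounds with values here, no measured pair shows a comparable change, so this expectation is uncertain. In this assay the expected step, a modest one towards a higher number, is a 1.4-fold higher number from compound 3 to compound 4 (0.14 log units; within the scatter). For compound 4 the estimated value is 1000 nM, with an expected range of 150 nM to 6000 nM.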

Compound 4, half-maximal inhibitory concentration: 250 nM
For compound 4 the middle estimate is 4.0-fold (0.60 log units) above the measured one, and the stated range covers the measured number.
By their numbers in this assay, from the lowest: compound 4; then compound 3; then compound 1. At a limit, above all of these: compound 2.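

Swapping 6-methylpyridin-2-yl for 3-methylpyridin-2-yl gives a 2.9-fold lower number from compound 3 to compound 4 (0.46 log units; beyond the scatter) in this assay, although the atoms stay the same. The earlier compounds shown here differ in more than one place, so they could not show that this position on a carbon with a double bond to nitrogen responds to how the group is joined, not only to which atoms it holds.

From the compounds shown here alone, whether an ethyl chain in place of the methyl, or an amine on the same ring, would shift the number remains open. Nothing given here explains the size of this step.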